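Ghrelin Receptor Antagonists: Swapping the Benzyl Ether Aryl Group

The compounds below may be only part of what the source reports. "The series", "measured", "known", "first", "only" and "open" are said of these compounds alone.

Compound 1, `CC(C)(N)C(=O)N[C@H](COCc1ccccc1Cl)c1nnnn1CCOC(=O)NCCCCO`: 0.45 nM
Compound 2, `CC(C)(N)C(=O)N[C@H](COCc1cccc(Cl)c1Cl)c1nnnn1CCOC(=O)NCCCCO`: 0.61 nM
Compound 3, `CC(C)(N)C(=O)N[C@H](COCc1cc(Cl)cc(Cl)c1)c1nnnn1CCOC(=O)NCCCCO`: 6.75 nM

Three compounds share a core and differ only in the aryl group of the benzyl ether. In a functional assay on cells for inhibition of growth hormone secretagogue receptor type 1 (Homo sapiens), read by FLIPR and calcium flux (a higher number here means that more compound is needed for the effect, a lower number that less compound is needed), compound 1 gives 0.45 nM and compound 2 gives 0.61 nM; the two lie within the scatter of each other, as the step of a 1.4-fold higher number from compound 1 to compound 2 (0.13 log units; within the scatter) shows. Compound 3 stands at the highest number of the three, with 6.75 nM in this assay, set apart from both others by the steps of a 15-fold higher number from compound 1 to compound 3 (1.18 log units; beyond the scatter) and an 11-fold higher number from compound 2 to compound 3 (1.04 log units; beyond the scatter).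

Compound 4, `CC(C)(N)C(=O)N[C@H](COCc1ccccc1C(F)(F)F)c1nnnn1CCOC(=O)NCCCCO`, is not yet measured. It differs from compound 3 in one place: 2-(trifluoromethyl)phenyl in place of 3,5-dichlorophenyl on a saturated chain carbon bound to an oxygen on a saturated carbon. The two large steps bear on this change in reverse, since each of them moved from a phenyl carrying a group at the 2-position to the 3,5-dichlorophenyl of compound 3. For the measured compounds named here, no measured compound carries a trifluoromethyl group, so the size is uncertain, but a large step to a lower number is expected, a 6.8-fold lower number from compound 3 to compound 4 (0.83 log units; beyond the scatter). Compound 4 is therefore estimated at 1 nM in this assay, within a range of 0.3 nM to 4 nM.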

Compound 4, half-maximal effective concentration: 0.72 nM
Compound 4: the middle estimate sits 1.4-fold (0.14 log units) above what was measured, within the range that was stated.
By their numbers in this assay, from the lowest: compounds 1, 2 and 4 (each within the scatter of the next); then compound 3.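

In this assay, the step of a 9.4-fold lower number from compound 3 to compound 4 (0.97 log units; beyond the scatter) shows that a chlorine-free aryl group at this position can also give a number well under that of the 3,5-dichlorophenyl compound. The steps of a 1.6-fold higher number from compound 1 to compound 4 (0.20 log units; within the scatter) and a 1.2-fold higher number from compound 2 to compound 4 (0.07 log units; within the scatter) lie within the scatter, so trifluoromethyl in place of chloro leaves no readable change, and among these four compounds only the 3,5-dichlorophenyl of compound 3 stands apart, while the 2-chlorophenyl, 2,3-dichlorophenyl and 2-(trifluoromethyl)phenyl groups read alike. Nothing at hand explains why the 3,5-dichlorophenyl group stands apart.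

The compounds shown leave open how an unsubstituted phenyl, or a phenyl carrying a methoxy group or a nitrile, would read in this assay. They also leave open whether the higher number of compound 3 needs both chloro groups or only one.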